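The compounds below may be only part of what the source reports. "The series", "measured", "known", "first", "only" and "open" are said of these compounds alone.

Measured in a physicochemical assay for solubility, with a stated time of 18 h, at pH 7.4; a lower number here means a less soluble compound, a higher number a more soluble compound:
compound 1 `COc1ccc(F)cc1CNCCCNc1ccnc2cc(Oc3cccc(N(C)C)c3)ccc12` gives 14500 nM
compound 2 `COc1ccc(-c2ccc3c(NCCCNCc4cc(F)ccc4OC)ccnc3c2)cc1` gives 32000 nM

Compound 2 has the highest of the two numbers in this assay, standing a 2.2-fold higher number from compound 1 to compound 2 (0.34 log units; beyond the scatter). Compound 3 `COc1ccc(F)cc1CNCCCNc1ccnc2cc(CCC(C)C)ccc12` differs from compound 2 by isopentyl in place of 4-methoxyphenyl on an aromatic carbon. Among the compounds with values here, the only measured step, from compound 1 to compound 2, concerns a different exchange at the same position, so it offers no direct guide to the isopentyl group. For compound 3 a step of a 1.3-fold lower number from compound 2 to compound 3 (0.11 log units; within the scatter) is therefore expected, lying within the scatter. Compound 3 is estimated at 25000 nM, with a range from 8000 nM to 70000 nM.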

Compound 3, solubility: 4200 nM
For compound 3 the middle estimate is 6.0-fold (0.77 log units) above the measured one, outside the stated range (below it).
By their numbers in this assay, from the lowest: compound 3; then compound 1; then compound 2.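

Isopentyl in place of 4-methoxyphenyl on this aromatic carbon gives a 7.6-fold lower number from compound 2 to compound 3 (0.88 log units; beyond the scatter) in this assay, so a group without a ring can move the number down here, whereas the earlier exchange between two ring-bearing groups moved it up. Isopentyl in place of 3-(dimethylamino)phenoxy likewise gives a 3.5-fold lower number from compound 1 to compound 3 (0.54 log units; beyond the scatter) in this assay, which leaves compound 3 lowest of the three. Nothing measured here explains this fall.

The compounds shown leave open whether cyclohexyl, a longer chain or an amine at this position would stay near compound 3 or return toward compound 1 and compound 2.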